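Compound 3 to compound 4: benzylamino on the chain

The source may report more compounds than this note shows. Statements on the series, on what has been measured and on what is new or still open speak of the compounds shown alone.

Measured in a functional assay on MCF7 cells (Homo sapiens) for antiproliferative activity (on this read-out higher numbers stand for weaker inhibition and lower numbers for stronger inhibition), as follows:
compound 1 `CCN(C)CCCOc1ccc2cc(NC(=O)c3ccc(O)c(CC=C(C)C)c3)c(=O)oc2c1C` | 2190 nM
compound 2 `COC(=O)CNCCCOc1ccc2cc(NC(=O)c3ccc(O)c(CC=C(C)C)c3)c(=O)oc2c1C` | 2820 nM
compound 3 `CC(C)=CCc1cc(C(=O)Nc2cc3ccc(OCCCN(C)c4ccccc4)c(C)c3oc2=O)ccc1O` | > 50000 nM

The entry for compound 3 reads > 50000 nM as a limit of this assay and not as a number.

Compound 4 `CC(C)=CCc1cc(C(=O)Nc2cc3ccc(OCCCNCc4ccccc4)c(C)c3oc2=O)ccc1O` is the next to be read. The change is benzylamino in place of methyl(phenyl)amino on a saturated chain carbon, three bonds along the chain from an oxygen on an aromatic ring and the two compounds have the same atoms, joined differently: benzylamino in place of methyl(phenyl)amino on a saturated chain carbon, three bonds along the chain from an oxygen on an aromatic ring.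

For the measured compounds named here, three measured steps bear on this. The step of a 1.3-fold higher number from compound 1 to compound 2 (0.11 log units; within the scatter) shows two different amine groups reading alike. The steps of an at least 22-fold higher number from compound 1 to compound 3 (1.35 log units; beyond the scatter) and an at least 17-fold higher number from compound 2 to compound 3 (1.24 log units; beyond the scatter) are both large, and only compound 3 carries phenyl on the amine nitrogen. That reading rests on a single compound. Going by the values given here, no measured compound carries benzylamino, so the range stays wide.

Compound 4 has no phenyl on the nitrogen, so it is expected to read close to compound 2 at 2820 nM in this assay rather than close to compound 3. A large move toward stronger inhibition is expected, estimated as an at least 14-fold lower number from compound 3 to compound 4 (1.15 log units; beyond the scatter) in size. The estimate for compound 4 is 3500 nM with an expected range from 1000 nM to 15000 nM in this series.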

Compound 4, half-maximal inhibitory concentration: 910 nM
Compound 4: middle estimate off by 3.8-fold (0.59 log units), on the high side, and the stated range ends above it.
By their numbers in this assay, from the lowest: compound 4; then compounds 1 and 2 (each within the scatter of the next). At a limit, above all of these: compound 3.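

In this assay, benzylamino in place of methyl(phenyl)amino on the same saturated chain carbon gives a large step with the same atoms joined differently: an at least 54-fold lower number from compound 3 to compound 4 (1.73 log units; beyond the scatter). Both groups hold one six-membered aromatic ring of carbon only, so the presence of that ring does not by itself go with the weak reading, while the two groups do differ in that benzylamino carries a hydrogen-bond donor and methyl(phenyl)amino carries none. The amine at this place also does more than split the series into one weak compound and a level group, since benzylamino gives modest gains over both earlier amines, with a 3.1-fold lower number from compound 2 to compound 4 (0.49 log units; beyond the scatter) and a 2.4-fold lower number from compound 1 to compound 4 (0.38 log units; beyond the scatter).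

Compound 3 stands at a limit, > 50000 nM, and not at a number, which leaves the full size of its step to compound 4 unknown: the limit of > 50000 nM in this assay, at which 1 of the 4 values shown sits.
Still open, on these data alone, is whether the reading follows the hydrogen on the nitrogen or the placing of the ring, which benzyl(methyl)amino and phenylamino would separate, and whether a longer link such as 2-phenylethylamino carries the gain further.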